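The source may hold more compounds than are shown below. What is called first, only, known or untested is meant among the compounds shown, and "the series" means these compounds.

In a functional assay on ileum (Cavia porcellus) for antagonist activity, with a stated time of 30 s (on this read-out higher numbers stand for weaker inhibition and lower numbers for stronger inhibition), compound 1 `O=C(O)c1cc(=O)c2ccc(OCCCOc3ccccc3)cc2o1` gives 1.4 ug/mL and compound 2 `O=C(O)c1cc(=O)c2ccc(OCCCCCCCOc3ccccc3)cc2o1` gives 1.8 ug/mL. These two values lie within the scatter of each other, so compound 2 stands level with compound 1. Compound 3 `O=C(O)c1cc(=O)c2ccc(OCCCCCSc3ccccc3)cc2o1` differs from compound 2 as follows: phenylsulfanyl in place of 2-phenoxyethyl on a saturated chain carbon, five bonds along the chain from an oxygen on an aromatic ring. For the measured compounds named here, no measured pair isolates this change. With compound 1 at 1.4 ug/mL and compound 2 at 1.8 ug/mL despite their different chains, no step beyond the scatter is expected in this assay. The expected change is a 1.1-fold lower number from compound 2 to compound 3 (0.05 log units; within the scatter). The estimate for compound 3 is 1.6 ug/mL, with an expected range of 0.7 ug/mL to 3.5 ug/mL.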

Compound 3, half-maximal inhibitory concentration: 0.4 ug/mL
Compound 3: middle estimate off by 4.0-fold (0.60 log units), on the high side, outside the stated range (below it).
By their numbers in this assay, from the lowest: compound 3; then compounds 1 and 2 (each within the scatter of the next).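

In this assay, phenylsulfanyl in place of 2-phenoxyethyl on a saturated chain carbon gives a 4.5-fold lower number from compound 2 to compound 3 (0.65 log units; beyond the scatter), and 2-(phenylsulfanyl)ethyl in place of phenoxy gives a 3.5-fold lower number from compound 1 to compound 3 (0.54 log units; beyond the scatter). The far end of the chain can therefore move this read-out beyond the scatter, toward stronger inhibition, which compound 1 and compound 2 alone did not show. No measurement here gives a reason for either step.

As far as these compounds go, whether the sulfur link or the chain carries the step stays open, since compound 3 differs from compound 1 and compound 2 in both. A phenoxy group on the chain of compound 3 would separate the two, and an amine in place of the sulfur would show how far this link tolerates change.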